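Methoxy on the Benzoyl Ring of a Diacylhydrazine

A few compounds are considered here, and "the series" means these few. Any claim that something is new, unique, unknown or untested is made for them only; others in the source may bear on it.

compound 1 `CC(C)(C)N(NC(=O)c1ccccc1)C(=O)c1ccccc1Cl` — 75.9 nM
compound 2 `Cc1cc(C)cc(C(=O)N(NC(=O)c2ccccc2)C(C)(C)C)c1` — 69.2 nM

In an assay on cells for agonist activity at ecdysone receptor (Bombyx mori), read by a luciferase reporter, with a stated time of 24 h (a lower number here means that less compound is needed, a higher number that more compound is needed for the effect), compound 2 gives 69.2 nM, and compound 1 gives 75.9 nM. For the measured compounds named here, the one step measured so far, a 1.1-fold lower number from compound 1 to compound 2 (0.04 log units; within the scatter), changes the aryl group on one carbonyl and stays within the scatter. Compound 3 `COc1cccc(C(=O)NN(C(=O)c2cc(C)cc(C)c2)C(C)(C)C)c1` differs from compound 2 on the other aryl group: methoxy in place of hydrogen on an aromatic carbon. Going by the values given here, no measured step touches this ring, so the only guide is that the one aryl change recorded did not move the number beyond the scatter. On that basis compound 3 is expected to give a number close to compound 2, with the step of a 1.0-fold higher number from compound 2 to compound 3 (0.00 log units; within the scatter) expected to remain within the scatter, and compound 3 is estimated at 70 nM, with a range from 30 nM to 170 nM.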

Compound 3, half-maximal effective concentration: 66.1 nM
Estimate against measurement, compound 3: 1.1-fold (0.02 log units) above, and the stated range covers the measured number.
By their numbers in this assay, from the lowest: compounds 3, 2 and 1 (each within the scatter of the next).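

For the compounds shown here, compound 1 and compound 2 spoke only to the aryl group on one carbonyl, whereas a 1.0-fold lower number from compound 2 to compound 3 (0.02 log units; within the scatter) gives the first reading on the other aryl group. In this assay, this step shows that phenyl can become 3-methoxyphenyl, with methoxy on an aromatic carbon meta to a large group, while the number stays within the scatter. This holds for a group of 2 heavy atoms carrying 1 hydrogen-bond acceptor, on the background of compound 2 only. Nothing on hand bears on the reason for this result.

The compounds shown leave open whether an amine, a carboxylic acid or a longer chain such as butoxy would stay within the scatter at this position. They also leave open whether methoxy would give the same result with the 2-chlorophenyl group of compound 1 on the other carbonyl.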